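This account rests on a few compounds, and the source may have more. Where it says the series, first, only, none or still open, it means among the compounds named here.

Measured compounds:
compound 1, `O=C(O)Cc1sc(Cc2ccccc2-c2ccccc2)nc1-c1ccc(Cl)cc1`: 41 nM
compound 2, `NS(=O)(=O)c1ccc(-c2nc(C(c3ccc(F)cc3)c3ccc(F)cc3)sc2CC(=O)O)cc1`: 1500 nM

In an in vitro assay on HEK385-7 cells for displacement of a labelled ligand from prostaglandin D2 receptor 2 (Homo sapiens) (on this read-out higher numbers stand for weaker inhibition and lower numbers for stronger inhibition), compound 2 gives the higher of the two numbers recorded, and its nearest neighbour is compound 1, whose value lies far below it, well beyond the usual scatter of this assay. Compound 3, `O=C(O)Cc1sc(C(c2ccc(F)cc2)c2ccc(F)cc2)nc1-c1ccnc(N2CCCC2)c1`, has not yet been measured. It differs from compound 2 in one place: 2-(pyrrolidin-1-yl)pyridin-4-yl in place of 4-sulfamoylphenyl on an aromatic carbon. The rest of the molecule, including the carboxymethyl group on the shared core and the large group two ring bonds away, is kept as in compound 2.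

Within the data shown here, no pair of measured compounds isolates this particular change, so there is no measured step on which the size of the effect could be read directly. Compound 3 is nevertheless expected to move in the direction of a lower number, since the shared core is held constant and only the aryl group on the aromatic carbon is exchanged; the step from compound 2 is estimated at a 3.0-fold lower number from compound 2 to compound 3 (0.48 log units; beyond the scatter), which is expected to exceed the scatter. Compound 3 is estimated at 500 nM, with a range from 100 nM to 2500 nM.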

Compound 3, half-maximal inhibitory concentration: 230 nM
Compound 3: middle estimate off by 2.2-fold (0.34 log units), on the high side; low and high end bracket the measured number.
By their numbers in this assay, from the lowest: compound 1; then compound 3; then compound 2.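

In this assay, among these compounds, the one measured change on the aromatic carbon next to the ring nitrogen, 2-(pyrrolidin-1-yl)pyridin-4-yl in place of 4-sulfamoylphenyl, gives a 6.5-fold lower number from compound 2 to compound 3 (0.81 log units; beyond the scatter), so this position responds to the choice of aryl group while the carboxymethyl group and the large group stay fixed. The step also shows that the number falls when the hydrogen-bond donor of the leaving group is lost and a five-membered non-aromatic ring is gained, although this single pair cannot separate those differences from the exchange of a carbon-only aromatic ring for one with a ring nitrogen. Nothing measured on these compounds accounts for the size or direction of the step.

On these data alone, it remains open whether the pyrrolidine ring or the pyridine nitrogen carries the step, a question that a plain phenyl group, or a morpholine ring in place of the pyrrolidine ring, would bear on. As far as these compounds go, compound 1 differs from both other compounds in more than one place, so it also remains open how this aryl change would read alongside the biphenyl-containing group of compound 1.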